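The source may report more compounds than this note shows. Statements on the series, on what has been measured and on what is new or still open speak of the compounds shown alone.

In a study of cytotoxicity, compound 1 `COc1ccc2c(=O)cc(C)[nH]c2c1` and compound 2 `CCCCCCCc1c(C)[nH]c2cc(OC)c(Cl)cc2c1=O` were tested in an ADME assay on J774 cells (Mus musculus) for cytotoxicity; a lower number here means that less compound is needed, a higher number that more compound is needed for the effect. For compound 1 the assay returned only a limit, > 52800 nM. For compound 2 the assay likewise reached only a limit, > 37100 nM. Within the data shown here, compound 2 thus stands at the edge of what this assay reports, with no number of its own, and the one other value shown is a limit as well (the limit of > 52800 nM in this assay, at which 1 of the 2 values shown sits). Compound 3 `CCCCC/C=C/c1c(C)[nH]c2cc(OC)c(Cl)cc2c1=O` differs from compound 2 in one place: hept-1-en-1-yl in place of heptyl on an aromatic carbon. Among the measured compounds shown here, no step between two measured compounds is available to guide the expectation. Because compound 2 sits at the limit (the limit of > 37100 nM in this assay, at which 1 of the 2 values shown sits), the expected step is a step that the limit leaves unreadable from compound 2 to compound 3, that is, none beyond the usual scatter. Compound 3 is therefore estimated at 50000 nM, within a range from 25000 nM to 100000 nM, and most likely reported again only as a limit.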

Compound 3, half-maximal effective concentration: > 31200 nM
Compound 3 gave a limit, no number (the forecaster's own chance of this, stated with the estimate: 75%); the middle value does not contradict the limit.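

Among these compounds, compound 2 and compound 3 both gave only limits, not numbers, and no step from one to the other can be read. The compounds shown leave open whether hept-1-en-1-yl in place of heptyl alters cytotoxicity in J774 cells at all.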